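Compound 4: cyclohexylmethyl on the carbonyl carbon

This account rests on a few compounds, and the source may have more. Where it says the series, first, only, none or still open, it means among the compounds named here.

In a functional assay on NCI-H460 cells (Homo sapiens) for cytotoxicity, read by MTT assay, with a stated time of 48 h (a lower number here means a stronger inhibitor, a higher number a weaker inhibitor), compound 3 `C=C1C(=O)O[C@H]2CC3=C[C@H](C/C(C)=C/[C@@H](OC(=O)/C=C/c4cccc(OC)c4)[C@H]12)OC3=O` gives > 10000 nM, a limit and not a number. Compound 1 `C=C1C(=O)O[C@H]2CC3=C[C@H](C/C(C)=C/[C@@H](OC(=O)c4ccc(C(F)(F)F)cc4)[C@H]12)OC3=O` gives > 10000 nM, also a limit. Compound 2 `C=C1C(=O)O[C@H]2CC3=C[C@H](C/C(C)=C/[C@@H](OC(=O)/C=C/c4ccc(N(C)C)cc4)[C@H]12)OC3=O` gives 1300 nM.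

Compound 4 `C=C1C(=O)O[C@H]2CC3=C[C@H](C/C(C)=C/[C@@H](OC(=O)CC4CCCCC4)[C@H]12)OC3=O` follows from compound 3 by cyclohexylmethyl in place of 2-(3-methoxyphenyl)ethenyl on a carbonyl carbon, with cyclohexylmethyl in place of 2-(3-methoxyphenyl)ethenyl on a carbonyl carbon.

Two readable steps bear on this change, an at least 7.6-fold lower number from compound 1 to compound 2 (0.88 log units; beyond the scatter) and an at least 7.6-fold higher number from compound 2 to compound 3 (0.88 log units; beyond the scatter). Both run through the 4-(dimethylamino)phenyl group of compound 2, which compound 4 does not carry. The other step, a step that the two limits leave unreadable from compound 1 to compound 3, gives no size.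

The expected result is no change beyond the scatter, a number no higher from compound 3 to compound 4 (the limit leaves the size open). The estimate for compound 4 is 10000 nM, with a range of 3000 nM to 30000 nM.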

Compound 4, half-maximal inhibitory concentration: 2000 nM
The estimate for compound 4 lay 5.0-fold (0.70 log units) above the measured number; measured number outside the range, below it.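

On the carbonyl carbon, an aromatic ring is not required for a readable value in this assay: cyclohexylmethyl, with its non-aromatic ring of carbon only, gives an at least 5.0-fold lower number from compound 3 to compound 4 (0.69 log units; beyond the scatter) and an at least 5.0-fold lower number from compound 1 to compound 4 (0.69 log units; beyond the scatter). Within the data shown here, the 2-(4-(dimethylamino)phenyl)ethenyl group of compound 2 is also not the only group giving a readable value, since cyclohexylmethyl is not separated from it: a 1.5-fold higher number from compound 2 to compound 4 (0.19 log units; within the scatter). The two steps from limits give only bounds on their size: the limit of > 10000 nM in this assay, at which 2 of the 4 values shown sit.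

As far as these compounds go, whether any ring is required at this place stays open. A straight hexyl chain or a piperidine ring on the carbonyl carbon would address this.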